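The compounds below may be only part of what the source reports. "The series", "measured", "known", "first", "only" and "open" are said of these compounds alone.

Compounds measured in a functional assay on A549 cells (Homo sapiens) for antiproliferative activity, read by MTT assay, with a stated time of 48 h; a lower number here means a stronger inhibitor, a higher number a weaker inhibitor:

Compound 1 `O=C(/C=C\Nc1ccc(F)cc1)c1cn(-c2ccccc2)nc1-c1ccc(F)cc1` gives 5780 nM.
Compound 2 `O=C(/C=C\Nc1ccc(Cl)cc1)c1cn(-c2ccccc2)nc1-c1ccc(F)cc1` gives 6700 nM.
Compound 3 `COc1ccc(N/C=C\C(=O)c2cn(-c3ccccc3)nc2-c2ccc(F)cc2)cc1` gives 8900 nM.

Compound 2 stands close to both of its neighbours: the step of a 1.2-fold higher number from compound 1 to compound 2 (0.06 log units; within the scatter) and the step of a 1.3-fold higher number from compound 2 to compound 3 (0.12 log units; within the scatter) are each within the scatter, as is the step of a 1.5-fold higher number from compound 1 to compound 3 (0.19 log units; within the scatter), so the three compounds cannot be told apart on these numbers.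

Compound 4 `O=C(/C=C\Nc1ccc(Cl)cc1)c1cn(-c2ccccc2)nc1-c1ccc(Cl)cc1` has not yet been measured. It differs from compound 2 by chloro in place of fluoro on an aromatic carbon. Going by the values given here, the one measured step that bears on this is the step of a 1.2-fold higher number from compound 1 to compound 2 (0.06 log units; within the scatter), the same exchange of chloro for fluoro carried out at a different aromatic carbon of the molecule; it stayed within the scatter. Among the compounds with values here, nothing among the measured compounds points to a change beyond the scatter in this assay for the present exchange either, so no step beyond the scatter is expected. This amounts to an expected step of a 1.0-fold higher number from compound 2 to compound 4 (0.02 log units; within the scatter). Compound 4 is therefore estimated at 7000 nM, with a range from 3500 nM to 14000 nM.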

Compound 4, half-maximal inhibitory concentration: 3670 nM
Compound 4: the middle estimate sits 1.9-fold (0.28 log units) above what was measured; low and high end bracket the measured number.
By their numbers in this assay, from the lowest: compounds 4, 1, 2 and 3 (each within the scatter of the next, the first and the last beyond it).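

In this assay the change from 4-fluorophenyl to 4-chlorophenyl gives a 1.8-fold lower number from compound 2 to compound 4 (0.26 log units; within the scatter) and so leaves compound 4 within the scatter of compound 2. Going by these compounds alone, this is the first reading of the exchange at this position, para to a large group on the shared core. Together with a 1.2-fold higher number from compound 1 to compound 2 (0.06 log units; within the scatter) at a different aromatic carbon, it shows chloro in place of fluoro staying within the scatter at both places tried, although no data shown here offer an explanation for this result. The compounds shown leave open whether a group other than these two halogens, such as an amine or a carboxylic acid, would produce a step beyond the scatter at this position. They also leave open whether chloro in place of fluoro would behave the same way on other versions of the core.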